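Switching the Amide Chain from Butyl to Isopropyl

A few compounds are considered here, and "the series" means these few. Any claim that something is new, unique, unknown or untested is made for them only; others in the source may bear on it.

compound 1 `CCNC(=O)C1=CC(C)(C)Oc2ccc([N+](=O)[O-])cc21`: 80.5%
compound 2 `CCCNC(=O)C1=CC(C)(C)Oc2ccc([N+](=O)[O-])cc21`: 74.1%
compound 3 `CCCCNC(=O)C1=CC(C)(C)Oc2ccc([N+](=O)[O-])cc21`: 83.2%

In a functional assay on the whole organism (muscle tissue) with Rattus norvegicus as the target (on this read-out higher numbers stand for larger maximal responses and lower numbers for smaller maximal responses), compound 3 gives 83.2%, the highest of the three numbers, yet the two steps leading to it, a number 2.7 percentage points higher from compound 1 to compound 3 (within the scatter) and a number 9.1 percentage points higher from compound 2 to compound 3 (within the scatter), both stay within the scatter, so the three compounds cannot be ranked. Compound 4 `CC(C)NC(=O)C1=CC(C)(C)Oc2ccc([N+](=O)[O-])cc21` differs from compound 3 in one place: isopropyl in place of butyl on an amide-type nitrogen. The measured steps all vary the chain on this same nitrogen, a number 6.4 percentage points lower from compound 1 to compound 2 (within the scatter), a number 2.7 percentage points higher from compound 1 to compound 3 (within the scatter) and a number 9.1 percentage points higher from compound 2 to compound 3 (within the scatter), and none moved the read-out beyond the scatter. Among the compounds with values here, no measured step introduces a branched chain, so the expectation rests on those lengthening steps alone. Compound 4 is therefore expected to give 79%, with a range from 66% to 92%. The expected step is a number 4.2 percentage points lower from compound 3 to compound 4 (within the scatter), within the scatter.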

Compound 4, intrinsic activity: the largest response reached, in percent of the reference agonist's: 77.6%
The estimate for compound 4 lay 1.4 percentage points above the measured number, within the range that was stated.
By their numbers in this assay, from the lowest: compounds 2, 4, 1 and 3 (each within the scatter of the next).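

Isopropyl brings the first branched chain to this amide-type nitrogen, and the maximal response in this assay stays within the scatter of all three straight-chain compounds: a number 5.6 percentage points lower from compound 3 to compound 4 (within the scatter), a number 3.5 percentage points higher from compound 2 to compound 4 (within the scatter) and a number 2.9 percentage points lower from compound 1 to compound 4 (within the scatter). Neither chain length nor this branching therefore separates the four compounds. Adding a methyl to a chain carbon also gives two steps that cannot be told apart: the same change on two cores in this assay, a number 9.1 percentage points higher (within the scatter) from compound 2 to compound 3 and a number 2.9 percentage points lower (within the scatter) from compound 1 to compound 4, 12 percentage points apart, within the scatter of two such steps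

From the compounds shown here alone, it remains open whether a cyclohexyl ring, a much longer chain, or a chain ending in an amine or a carboxylic acid would move the response beyond the scatter.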